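Lengthening the acid-bearing chain on a lipopeptide agonist

This account rests on a few compounds, and the source may have more. Where it says the series, first, only, none or still open, it means among the compounds named here.

Of the compounds shown here, three built on the same lipidated core have been tested in an assay on HEK293 cells for agonist activity at Toll-like receptor 2 (Homo sapiens); a lower number here means that less compound is needed, a higher number that more compound is needed for the effect. Compound 1, `CCCCCCCCCCCC(=O)OC[C@H](CSC[C@@H](N)C(=O)N[C@@H](C)CO)OC(=O)CCCCCCCCCCC`, gives 1560 nM. Compound 2, `CCCCCCCCCCCC(=O)OC[C@H](CSC[C@@H](N)C(=O)NC1(CO)CC1)OC(=O)CCCCCCCCCCC`, gives 265 nM. Compound 3, `CCCCCCCCCCCC(=O)OC[C@H](CSC[C@@H](N)C(=O)NCCCCCC(=O)O)OC(=O)CCCCCCCCCCC`, gives 108 nM. Compound 2 therefore stands second highest of the three numbers: the step of a 2.5-fold lower number from compound 2 to compound 3 (0.39 log units; beyond the scatter) separates it from its nearest neighbour, while the step of a 5.9-fold lower number from compound 1 to compound 2 (0.77 log units; beyond the scatter) separates it from the furthest. The step of a 14-fold lower number from compound 1 to compound 3 (1.16 log units; beyond the scatter) spans the whole set.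

Compound 4, `CCCCCCCCCCCC(=O)OC[C@H](CSC[C@@H](N)C(=O)NCCCCCCCCCC(=O)O)OC(=O)CCCCCCCCCCC`, has not yet been measured. Compared with compound 2 the change is 9-carboxynonyl in place of 1-(hydroxymethyl)cyclopropyl on an amide-type nitrogen.

The step that bears most directly on this change is a 2.5-fold lower number from compound 2 to compound 3 (0.39 log units; beyond the scatter), in which a shorter carboxy-terminated chain also replaced the hydroxymethyl-bearing ring at the same amide nitrogen and gave a modest lowering. For the measured compounds named here, no measured pair shows what extra chain length beyond 5-carboxypentyl does, so a step of similar size, downward, is the expectation, with wide uncertainty. Compound 4 is estimated at 100 nM, with a likely range from 30 nM to 330 nM. For compound 4 the expected step is a 2.7-fold lower number from compound 2 to compound 4 (0.42 log units; beyond the scatter).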

Compound 4, half-maximal effective concentration: 4400 nM
For compound 4 the middle estimate is 44-fold (1.64 log units) below the measured one; the whole stated range lies below it.
By their numbers in this assay, from the lowest: compound 3; then compound 2; then compound 1; then compound 4.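

Lengthening the acid-bearing chain at the amide-type nitrogen reverses the gain seen with 5-carboxypentyl: 9-carboxynonyl gives a 41-fold higher number from compound 3 to compound 4 (1.61 log units; beyond the scatter) in this assay, the largest step in this set. A carboxy group at the end of a chain is therefore not enough on its own to give a low number at this position, since 9-carboxynonyl also carries one and yet gives a 17-fold higher number from compound 2 to compound 4 (1.22 log units; beyond the scatter) and a 2.8-fold higher number from compound 1 to compound 4 (0.45 log units; beyond the scatter) when it replaces the two hydroxymethyl-bearing groups. Among these compounds, the length of the chain matters at least as much as the group at its end, but nothing available explains the sharp rise in the number with the longer chain.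

For the compounds shown here, with only two acid-bearing chain lengths, it remains open whether the number climbs steadily from 5-carboxypentyl to 9-carboxynonyl or turns sharply at one length, which a chain of intermediate length such as 7-carboxyheptyl could help settle. The role of the acid is also unresolved, and unbranched chains of the same lengths ending in an amine or a plain methyl group would separate its contribution from that of chain length.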